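Sulfur substituent change in a purine riboside series

A few compounds are considered here, and "the series" means these few. Any claim that something is new, unique, unknown or untested is made for them only; others in the source may bear on it.

Of the compounds shown here, three have been measured in an assay on isolated protein for binding affinity to Equilibrative nucleoside transporter 1 (Homo sapiens); a higher number here means a weaker inhibitor, a lower number a stronger inhibitor. Compound 1 `O=[N+]([O-])c1ccc2c(c1)CN(c1ncnc3c1nc1n3[C@@H]3O[C@H](CO1)[C@@H](O)[C@H]3O)CC2` gives 331 nM. Compound 2 `O=[N+]([O-])c1cccc2c1CN(c1ncnc3c1nc1n3[C@@H]3O[C@H](CO1)[C@@H](O)[C@H]3O)CC2` gives 1740000 nM. Compound 3 `Nc1nc(SCc2ccc(Br)cc2)c2ncn([C@@H]3O[C@H](CO)[C@@H](O)[C@H]3O)c2n1` gives 813 nM. Among these three numbers compound 3 stands second highest. Its nearest neighbour is compound 1, with a lower number, and that gap lies beyond the usual scatter; compound 2 sits far above it at the weak end, a gap also well beyond the scatter.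

Compound 4 `CC(=O)c1ccccc1Sc1nc(N)nc2c1ncn2[C@@H]1O[C@H](CO)[C@@H](O)[C@H]1O` has not yet been measured in this assay. Its difference from compound 3 is as follows: 2-acetylphenyl in place of 4-bromobenzyl on a sulfur. No measured pair in this set differs in one place, so the size of a step of this kind is not shown by any measured pair, and compound 1 and compound 2 share a different core that gives no guidance on the sulfur substituent. The expected step is a 2.5-fold higher number from compound 3 to compound 4 (0.39 log units; beyond the scatter), a moderate rise in the number towards a weaker inhibitor. A result within the scatter would, however, not be surprising. Compound 4 is expected to give about 2000 nM in this assay, with a likely range from 500 nM to 8000 nM.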

Compound 4, half-maximal inhibitory concentration: 447000 nM
Compound 4: the middle estimate sits 220-fold (2.35 log units) below what was measured; measured number above the stated range.
By their numbers in this assay, from the lowest: compound 1; then compound 3; then compound 4; then compound 2.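

Exchanging 4-bromobenzyl for 2-acetylphenyl on the sulfur gives a 550-fold higher number from compound 3 to compound 4 (2.74 log units; beyond the scatter) in this assay and so shows that this position is highly sensitive to the nature of its substituent. Both substituents carry one six-membered aromatic ring of carbon only, so the presence of such a ring on the sulfur does not by itself preserve the sub-micromolar-range number that compound 3 gives at 813 nM in this series. The change is nevertheless composite: the benzyl gives way to a phenyl, the bromine leaves, and an acetyl with its hydrogen-bond acceptor enters, so the step cannot be divided among these parts.

The compounds shown leave open which part of the exchange carries the loss, and a plain phenyl, a plain benzyl or a 2-acetylbenzyl on the sulfur would separate these contributions, while nothing here gives a reason for the size of the step.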